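A few compounds are considered here, and "the series" means these few. Any claim that something is new, unique, unknown or untested is made for them only; others in the source may bear on it.

Compound 2 `O=C(CCc1ccccc1)c1ccccc1OCC(O)CNc1ccccc1` stands as the higher of the two numbers measured in a functional assay on CCRF-CEM/VCR-1000 cells (Homo sapiens) for inhibition; on this read-out lower numbers stand for stronger inhibition and higher numbers for weaker inhibition: compound 2 gives 6470 nM, whereas compound 1 `CCCNCC(O)COc1ccc(OCc2ccccc2)cc1C(=O)CCc1ccccc1` gives 110 nM, a gap well beyond the usual scatter. Compound 3 `CN(C)CC(O)COc1ccccc1C(=O)CCc1ccccc1` carries dimethylamino in place of anilino on a saturated chain carbon, two bonds along the chain from an oxygen on a saturated carbon. Among the compounds with values here, no measured pair isolates this change, and compound 1 differs from compound 2 in more than one place, so only a moderate step toward a lower number is expected, namely a 3.2-fold lower number from compound 2 to compound 3 (0.51 log units; beyond the scatter). Compound 3 is accordingly estimated at 2000 nM in this assay, with a range from 500 nM to 8000 nM.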

Compound 3, half-maximal inhibitory concentration: 2640 nM
Compound 3: the middle estimate sits 1.3-fold (0.12 log units) below what was measured, within the range that was stated.
By their numbers in this assay, from the lowest: compound 1; then compound 3; then compound 2.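

In this assay, within the data shown here, dimethylamino in place of anilino gives a 2.5-fold lower number from compound 2 to compound 3 (0.39 log units; beyond the scatter), the first comparison that isolates a change at this position. Losing the ring and the hydrogen-bond donor of anilino therefore moves the number only modestly, though beyond the scatter, and the change does not bring compound 3 to the value of compound 1. No evidence is available on what underlies this step. Going by these compounds, whether a cyclic amine such as piperidino or morpholino at this position would give a lower or higher number remains open. On these data alone, how much of the lower number of compound 1 comes from its amine also remains open, as compound 1 differs from compound 3 in more than one place.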